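The compounds below may be only part of what the source reports. "The series", "measured", "known", "first", "only" and "open" are said of these compounds alone.

In a functional assay on A549 cells (Homo sapiens) for inhibition, read by sulforhodamine B assay, with a stated time of 48 h (on this read-out higher numbers stand for weaker inhibition of growth and lower numbers for stronger inhibition of growth), two compounds that share one core have been measured so far. Compound 1 (`COc1ccc(/C=C/C(=O)C(=Cc2ccc(O)c(OC)c2)C(=O)/C=C/c2ccc(OC)cc2)cc1`) gives 1640 nM, and compound 2 (`COc1ccc(/C=C/C(=O)C(=Cc2cc(OC)c(OC)c(OC)c2)C(=O)/C=C/c2ccc(OC)c(OC)c2)cc1OC`) gives 230 nM. Compound 2 therefore holds the lower of the two numbers, meaning stronger inhibition of growth, and the gap between them lies beyond the usual scatter of repeated measurements. Compound 3 (`COc1ccc(/C=C/C(=O)C(=Cc2ccc(N(C)C)cc2)C(=O)/C=C/c2ccc(OC)c(OC)c2)cc1OC`) differs from compound 2 in one place: 4-(dimethylamino)phenyl in place of 3,4,5-trimethoxyphenyl on a double-bonded chain carbon bound to a double-bonded chain carbon. For the measured compounds named here, no measured pair shows a change of this kind, so any expectation here is rough. A moderate rise in the number, towards weaker inhibition, is expected in this assay, since compound 2 at 230 nM is the lowest number seen so far. The estimated step is a 2.2-fold higher number from compound 2 to compound 3 (0.34 log units; beyond the scatter). For compound 3 the estimated value is 500 nM, with an expected range of 130 nM to 1900 nM.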

Compound 3, concentration for 50% growth inhibition: 2620 nM
For compound 3 the middle estimate is 5.2-fold (0.72 log units) below the measured one; the measured number lies above the stated range.
By their numbers in this assay, from the lowest: compound 2; then compounds 1 and 3 (each within the scatter of the next).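

In this assay, putting 4-(dimethylamino)phenyl in place of 3,4,5-trimethoxyphenyl on a double-bonded chain carbon bound to a double-bonded chain carbon gives an 11-fold higher number from compound 2 to compound 3 (1.06 log units; beyond the scatter). For the compounds shown here, this is the first change at a single place to be measured on the shared core, and it shows that the group at this position strongly affects growth inhibition, with the swap weakening it substantially. The change also lowers the counts from 12 heavy atoms and 3 hydrogen-bond acceptors to 9 and 1, but nothing measured here connects the loss of inhibition to these counts or to any other feature.

A single step cannot show whether the loss comes from removing the three methoxy groups or from adding the dimethylamino group. It also leaves open how a phenyl ring carrying a chloro group or a carboxylic acid would behave at this position.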